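Extending an Alkyl Chain: Expected Shift in Lipophilicity

This account rests on a few compounds, and the source may have more. Where it says the series, first, only, none or still open, it means among the compounds named here.

Three compounds have been measured in a physicochemical assay for lipophilicity; on this read-out lower numbers stand for lower lipophilicity and higher numbers for higher lipophilicity:
compound 1 `CCCc1ccc2[nH]c(-c3ccccc3)c(C3=C(Br)C(=O)NC3=O)c2c1` gives 3.43;
compound 2 `CCCCCc1ccc2[nH]c(-c3ccccc3)c(C3=C(Br)C(=O)NC3=O)c2c1` gives 4.07;
compound 3 `CCCCc1cccc2c(C3=C(Br)C(=O)NC3=O)c(-c3ccc(OC)cc3)[nH]c12` gives 3.81.

Compound 2 differs from compound 1 by a single change, (ethyl in place of hydrogen on a saturated chain carbon, three bonds along the chain from an aromatic carbon). In this assay that change gave a number 0.64 log units higher from compound 1 to compound 2 (beyond the scatter). Compound 4 `CCCCCCc1cccc2c(C3=C(Br)C(=O)NC3=O)c(-c3ccc(OC)cc3)[nH]c12` has not yet been measured; it differs from compound 3 by ethyl in place of hydrogen on a saturated chain carbon, four bonds along the chain from an aromatic carbon. The two places are not worded alike: in the first pair the chain carbon lies three bonds along the chain from an aromatic carbon, in the second four bonds, so this is the same kind of change rather than the same one. The difference between the two cores is not broken down here. Because the earlier step is a number 0.64 log units higher from compound 1 to compound 2 (beyond the scatter), a step of similar size is expected, a number 0.64 log units higher from compound 3 to compound 4 (beyond the scatter). Compound 4 is therefore estimated at 4.45, expected to lie between 4.1 and 4.8.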

Compound 4, partition coefficient: 4.27
For compound 4 the middle estimate is 0.18 log units above the measured one; the measured number falls inside the stated range.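

The new step in this assay is a number 0.46 log units higher from compound 3 to compound 4 (beyond the scatter) and the earlier step is a number 0.64 log units higher from compound 1 to compound 2 (beyond the scatter) so this change went with a higher number on both cores. Two pairs cannot show that it would do the same on a further core, and since the chain carbon lies three bonds along the chain from an aromatic carbon in one pair and four in the other, core and place cannot be told apart. Nothing available here explains the size of either step.

Still open, going by these compounds, is how a longer chain such as octyl would read on either core. On these data alone, an amine or a carboxylic acid in place of the ethyl also remains open.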